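A few compounds are considered here, and "the series" means these few. Any claim that something is new, unique, unknown or untested is made for them only; others in the source may bear on it.

Measured in a physicochemical assay for lipophilicity, read by LC-MS, in phosphate buffer, measured as octanol-water partition, with a stated time of 30 min, at pH 7.4, tested at 200 mM; on this read-out higher numbers stand for higher lipophilicity and lower numbers for lower lipophilicity:
- compound 1 `Cn1c(COc2cccc(C(=O)O)c2)nc2ccc(Oc3cc(Cl)ccn3)cc21`: 1.2
- compound 2 `Cc1ccc(Oc2ccc3nc(COc4cccc(C(=O)O)c4)n(C)c3c2)nc1`: 0.9
- compound 3 `Cc1cccnc1Oc1ccc2nc(COc3cccc(C(=O)O)c3)n(C)c2c1`: 0.9

Compound 3 stands level with compound 2 at the digits shown, and all three values lie within the scatter of one another. Compound 4 `Cc1ccc(C)c(Oc2ccc3nc(COc4cccc(C(=O)O)c4)n(C)c3c2)n1` carries one change relative to compound 3: methyl in place of hydrogen on an aromatic carbon. This turns 3-methylpyridin-2-yl into 3,6-dimethylpyridin-2-yl.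

For the measured compounds named here, no measured step makes this same change, so the evidence is indirect. The nearest steps exchange the group on the same oxygen. They are a number 0.30 log units lower from compound 1 to compound 2 (within the scatter), a number 0.30 log units lower from compound 1 to compound 3 (within the scatter) and no change at the digits printed from compound 2 to compound 3 (within the scatter). None of them goes beyond the scatter. Given the size of a number 0.30 log units lower from compound 1 to compound 3 (within the scatter), only a small upward step is expected in this assay on adding the methyl, near the edge of the scatter. The estimated step is a number 0.30 log units higher from compound 3 to compound 4 (within the scatter). For compound 4 the expected value is 1.2, with an estimated range from 0.9 to 1.6.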

Compound 4, distribution coefficient: 1.4
Compound 4: middle estimate off by 0.20 log units, on the low side; low and high end bracket the measured number.
By their numbers in this assay, from the lowest: compounds 2, 3, 1 and 4 (each within the scatter of the next, the first and the last beyond it).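

In this assay, methyl in place of hydrogen next to the ring nitrogen gives a number 0.50 log units higher from compound 3 to compound 4 (beyond the scatter), and this is the first single change among these compounds to go beyond the scatter. Exchanging 5-methylpyridin-2-yl for 3,6-dimethylpyridin-2-yl gives a step of the same size, a number 0.50 log units higher from compound 2 to compound 4 (beyond the scatter), whereas exchanging 4-chloropyridin-2-yl for that group gives only a number 0.20 log units higher from compound 1 to compound 4 (within the scatter). Nothing available explains why this methyl shifts the number.

From the compounds shown here alone, it remains open whether another group at this place, such as an amine, a methoxy group or a longer alkyl chain, would shift the number in the same direction. Going by these compounds, it is also open whether adding methyl at this place on the 4-chloropyridin-2-yl or 5-methylpyridin-2-yl group would give a step of similar size.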